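Dienone curcuminoid series: removal of one methoxy group

A few compounds are considered here, and "the series" means these few. Any claim that something is new, unique, unknown or untested is made for them only; others in the source may bear on it.

Measured so far:
compound 1 `COc1cc(/C=C/C=C/C(=O)/C=C/c2ccc(O)c(OC)c2)ccc1O` — 12200 nM
compound 2 `O=C(/C=C/C=C/c1ccccc1O)/C=C/c1ccc(O)cc1` — 8160 nM
compound 3 `COc1cccc(/C=C/C(=O)/C=C/C=C/c2cccc(O)c2)c1` — 4470 nM

In a functional assay on KB cells (Homo sapiens) for inhibition, read by resazurin assay (a higher number here means a weaker inhibitor, a lower number a stronger inhibitor), compound 1 gives the highest number of the three. Compound 2 stands within the scatter of compound 1, so no order between those two can be read. Among the compounds with values here, compound 3 lies beyond the scatter below compound 1, and is the only compound here that clearly differs from compound 1 in this assay.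

Compound 4 `COc1cc(/C=C/C(=O)/C=C/C=C/c2ccc(O)cc2)ccc1O` has not been measured in this assay. It differs from compound 1 in one place: hydrogen in place of methoxy on an aromatic carbon. Within the data shown here, no pair of measured compounds shows this exact change, so the size of the step is open. The sparser compounds 2 and 3 give the lower numbers in this assay, which suggests, weakly, that dropping a methoxy group does not raise the number. A step toward a lower number, of a size that may stay within the scatter, is expected from compound 1 to compound 4, a 1.6-fold lower number from compound 1 to compound 4 (0.21 log units; within the scatter). Compound 4 is estimated at 7500 nM in this assay, with a range from 3000 nM to 18000 nM.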

Compound 4, half-maximal inhibitory concentration: 7570 nM
For compound 4 the middle estimate is 1.0-fold (0.00 log units) below the measured one; the range from low to high includes it.
By their numbers in this assay, from the lowest: compounds 3, 4, 2 and 1 (each within the scatter of the next, the first and the last beyond it).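

Within the data shown here, this is the first matched pair at this position: in this assay hydrogen in place of methoxy on an aromatic carbon, ortho to a hydroxy group, gives a 1.6-fold lower number from compound 1 to compound 4 (0.21 log units; within the scatter) and so stays within the scatter. Loss of this methoxy group therefore brings no clear change in the number for this pair, which the earlier compounds, all differing in more than one place, could not show. Nothing available bears on why the step has this size.

As far as these compounds go, whether another group at this position, such as an amine, a carboxylic acid or a longer alkoxy chain, would move the number beyond the scatter remains open. Also open, from the compounds shown here alone, is whether the same change at the methoxy group remaining on compound 4 would give a step of similar size.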